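The source may report more compounds than this note shows. Statements on the series, on what has been measured and on what is new or still open speak of the compounds shown alone.

For the measured compounds named here, in an assay on isolated protein for inhibition of neutral cholesterol ester hydrolase 1 (Homo sapiens) (a lower number here means a stronger inhibitor, a higher number a weaker inhibitor), the compounds measured so far are these.
Compound 1 `O=C(CCCCCCc1ccccc1)c1ncno1` gives 25000 nM.
Compound 2 `O=C(CCCCCCc1ccccc1)c1nc(-c2ccccn2)no1` gives 30000 nM.
Compound 3 `COC(=O)c1cccc(-c2cnc(C(=O)CCCCCCc3ccccc3)s2)n1` gives > 100000 nM, a limit of the assay rather than a number.

Compound 1 holds the lowest of the two numbers, with compound 2 close by: a 1.2-fold higher number from compound 1 to compound 2 (0.08 log units; within the scatter). Compound 4 `O=C(CCCCCCc1ccccc1)c1nncs1` differs from compound 1 in one place: 1,3,4-thiadiazol-2-yl in place of 1,2,4-oxadiazol-5-yl on a carbonyl carbon. Going by the values given here, the only measured step adds a pyridinyl group to the ring and says nothing about exchanging one five-membered ring for another on the carbonyl carbon. Among the compounds with values here, compound 3 carries a different ring with a further substituent and reaches only a limit (the limit of > 100000 nM in this assay, at which 1 of the 3 values shown sits), so it gives no step to lean on. With no guide, the ring swap is expected to stay within the scatter, an estimated step of no change at the digits printed from compound 1 to compound 4 (within the scatter). Compound 4 is therefore expected near 25000 nM, between 8000 nM and 80000 nM.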

Compound 4, half-maximal inhibitory concentration: > 100000 nM
Compound 4 ended at the assay's limit; the forecaster's own chance of this, stated with the estimate: 20%; middle value at least 4.0-fold (0.60 log units) away from the limit.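

In this assay, the group on the carbonyl carbon proves not to be freely exchangeable: 1,3,4-thiadiazol-2-yl in place of 1,2,4-oxadiazol-5-yl, with matching counts of heavy atoms, donors and acceptors, gives an at least 4.0-fold higher number from compound 1 to compound 4 (0.60 log units; beyond the scatter). Compound 4 gives > 100000 nM, a limit of the assay and not a number. The full size of the step therefore cannot be read: the limit of > 100000 nM in this assay, at which 2 of the 4 values shown sit.

Still open, as far as these compounds go, is whether an amine on the 1,3,4-thiadiazol-2-yl ring, or a longer chain on the carbonyl carbon, would bring a measurable number back.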